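Amino to Phenyl on a Carbonyl: Expected Effect

The compounds below may be only part of what the source reports. "The series", "measured", "known", "first", "only" and "open" are said of these compounds alone.

Measured compounds:
compound 1, `N#C/C(=C\N1CCN(C(=O)c2ccco2)C1=S)C(N)=O`: 23500 nM
compound 2, `COc1cc(C(=O)N2CCN(C=O)C2=S)cc(OC)c1OC`: 70 nM
compound 3, `O=CN1CCN(c2cc(Cl)cc(Cl)c2)C1=S`: "not determined" (no result reported)

For the measured compounds named here, three compounds were tested in a functional assay on UO-31 cells (Homo sapiens) for inhibition, read by sulforhodamine B assay, with a stated time of 48 h (on this read-out higher numbers stand for weaker inhibition of growth and lower numbers for stronger inhibition of growth), but only two gave a number. Compound 1 gives 23500 nM, the higher of those two numbers and therefore the weaker inhibition of growth. Compound 2 gives 70 nM, a much lower number, and this gap lies well beyond the scatter of repeated measurements. Compound 3 carries "not determined" (no result reported).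

Compound 4, `N#C/C(=C\N1CCN(C(=O)c2ccco2)C1=S)C(=O)c1ccccc1`, shares its core with compound 1 and differs in one place: phenyl in place of amino on a carbonyl carbon. Going by the values given here, no step between measured compounds shows what such a change does, so there is no direct guide. Because compound 1 sits at 23500 nM, the estimate for compound 4 is kept close to it, with a modest shift toward stronger inhibition and a wide range. The step from compound 1 to compound 4 is expected to be a 2.0-fold lower number from compound 1 to compound 4 (0.29 log units; within the scatter). Compound 4 is estimated at 12000 nM, between 2500 nM and 60000 nM.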

Compound 4, concentration for 50% growth inhibition: 10200 nM
Estimate against measurement, compound 4: 1.2-fold (0.07 log units) above, and the stated range covers the measured number.
By their numbers in this assay, from the lowest: compound 2; then compound 4; then compound 1.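

In this assay the swap of amino for phenyl on a carbonyl carbon gives a 2.3-fold lower number from compound 1 to compound 4 (0.36 log units; beyond the scatter) and is the only step shown that changes a single place on the shared core. This modest step shows that the position can take phenyl, with its six heavy atoms and aromatic ring, in place of amino, with its one nitrogen and hydrogen-bond donor, without weaker inhibition of growth. No measurement shown here accounts for the step.

A single step cannot show whether the number tracks the size of the group or some other feature of it. Still open, as far as these compounds go, is how a methyl group, a pyridyl ring or a phenyl ring carrying a methoxy group on this same carbonyl carbon would compare with phenyl.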